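Diaryl urea series: swapping trifluoromethyl for chloro

The compounds below may be only part of what the source reports. "The series", "measured", "known", "first", "only" and "open" are said of these compounds alone.

For the measured compounds named here, compound 2 `COc1cc2cc(Oc3ccc(NC(=O)Nc4ccc(Cl)c(C(F)(F)F)c4)cc3)c(C)nc2cc1OC` gives 4910 nM in a functional assay on NCI/ADR-RES cells (Homo sapiens) for inhibition, read by sulforhodamine B assay, with a stated time of 48 h (on this read-out higher numbers stand for weaker inhibition of growth and lower numbers for stronger inhibition of growth), and holds the lowest of the two numbers so far; its nearest neighbour is compound 1 `COc1cc2cc(Oc3ccc(NC(=O)Nc4cccc(C(F)(F)F)c4)cc3)c(C)nc2cc1OC`, which gives 7190 nM. Going by the values given here, the one step between them, a 1.5-fold lower number from compound 1 to compound 2 (0.17 log units; within the scatter), stays within the scatter. Compound 3 `COc1cc2cc(Oc3ccc(NC(=O)Nc4ccc(Cl)c(Cl)c4)cc3)c(C)nc2cc1OC` differs from compound 2 by chloro in place of trifluoromethyl on an aromatic carbon. Among the compounds with values here, no measured step exchanges a trifluoromethyl for a chloro; the only step at hand, from compound 1 to compound 2, concerns a different position and is small, so it bears on the new change only as a sign that this edge of the molecule tolerates small changes. The expectation for this assay is therefore no step beyond the scatter, with a 1.0-fold higher number from compound 2 to compound 3 (0.01 log units; within the scatter) as the estimated step. Compound 3 is estimated at 5000 nM, within a range of 2000 nM to 12500 nM.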

Compound 3, concentration for total growth inhibition: 16900 nM
For compound 3 the middle estimate is 3.4-fold (0.53 log units) below the measured one; the whole stated range lies below it.
By their numbers in this assay, from the lowest: compounds 2 and 1 (each within the scatter of the next); then compound 3.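

In this assay, for the compounds shown here, this position, ortho to a chloro group, gives the first exchange that goes beyond the scatter: a 3.4-fold higher number from compound 2 to compound 3 (0.54 log units; beyond the scatter), whereas the earlier chloro step stayed within it. In this pair, then, trifluoromethyl cannot be exchanged for chloro without weaker inhibition of growth, so the tolerance suggested by the earlier step does not extend to this change. Going by these compounds alone, the 3,4-dichlorophenyl group also falls behind the 3-(trifluoromethyl)phenyl group, with a 2.4-fold higher number from compound 1 to compound 3 (0.37 log units; beyond the scatter), which leaves compound 3 with the highest number of the series so far.

No measurement at hand offers an explanation for this step. As far as these compounds go, whether bromo, methyl or a nitrile at this position would stay with trifluoromethyl or fall with chloro remains open, as does whether the step holds without the neighbouring chloro.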